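Replacing 4-bromo-2-fluorophenyl with 3-fluorophenyl in compound 3

The compounds below may be only part of what the source reports. "The series", "measured", "known", "first", "only" and "open" are said of these compounds alone.

Compound 1 `CCNC(=O)c1cc(Oc2ccc(NC(=O)c3nn(-c4ccccc4OC(F)(F)F)c(=O)cc3C)cc2)ccn1`: 3990 nM
Compound 2 `CCNC(=O)c1cc(Oc2ccc(NC(=O)c3nn(-c4ccc(Br)cc4F)c(=O)cc3C)cc2)ccn1`: "not active" (no number reported)
Compound 3 `CCCNC(=O)c1cc(Oc2ccc(NC(=O)c3nn(-c4ccc(Br)cc4F)c(=O)cc3C)cc2F)ccn1`: 53500 nM

In a functional assay on HeLa cells (Homo sapiens) for antiproliferative activity, read by MTT assay, with a stated time of 72 h (on this read-out lower numbers stand for stronger inhibition and higher numbers for weaker inhibition), compound 3 stands at 53500 nM, the higher of the two numbers, and compound 2 was reported only as "not active" (no number reported). Compound 4 `CCCNC(=O)c1cc(Oc2ccc(NC(=O)c3nn(-c4cccc(F)c4)c(=O)cc3C)cc2F)ccn1` differs from compound 3 by having 3-fluorophenyl in place of 4-bromo-2-fluorophenyl on an aromatic nitrogen. Among the measured compounds shown here, no measured pair isolates this change, so the expectation is loose. The only lower number belongs to compound 1 at 3990 nM, which shows that lower numbers occur among these compounds. A modest step toward a lower number is expected, estimated as a 2.7-fold lower number from compound 3 to compound 4 (0.43 log units; beyond the scatter). For compound 4 the expected value is 20000 nM, with an estimated range of 5000 nM to 70000 nM.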

Compound 4, half-maximal inhibitory concentration: 6660 nM
Estimate against measurement, compound 4: 3.0-fold (0.48 log units) above; the measured number falls inside the stated range.
By their numbers in this assay, from the lowest: compounds 1 and 4 (each within the scatter of the next); then compound 3.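

In this assay, exchanging 4-bromo-2-fluorophenyl for 3-fluorophenyl on the aromatic nitrogen gives an 8.0-fold lower number from compound 3 to compound 4 (0.90 log units; beyond the scatter) with the rest of the molecule unchanged. This is the first single-place change among these compounds, and it shows that the group at this position can by itself move the number beyond the scatter. No evidence at hand explains this shift.

The compounds shown do not separate the loss of the bromine from the change in the fluorine's place. From the compounds shown here alone, how a plain phenyl or a pyridyl group would read at this position remains open.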